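The source may hold more compounds than are shown below. What is called first, only, known or untested is meant among the compounds shown, and "the series" means these compounds.

Measured in an assay on CHO-K1 cells for displacement of a labelled ligand from 5-hydroxytryptamine receptor 1D (Homo sapiens), read by scintillation counting; a higher number here means a weaker inhibitor, a lower number a stronger inhibitor:
Compound 1 `O=C(Nc1ccc2[nH]cc(C3CCN(CCCN4CCC(c5c[nH]c6ccc(NC(=O)c7ccc(F)cc7)cc56)CC4)CC3)c2c1)c1ccc(F)cc1`: 79 nM
Compound 2 `O=C(Nc1ccc2[nH]cc(C3CCN(CCCCCCCCCCCN4CCC(c5c[nH]c6ccc(NC(=O)c7ccc(F)cc7)cc56)CC4)CC3)c2c1)c1ccc(F)cc1`: 13 nM
Compound 3 `CCCCCCCCN1CCC(c2c[nH]c3ccc(NC(=O)c4ccc(F)cc4)cc23)CC1`: > 1000 nM

Compound 3 stands apart from the other two entries. For compound 3 this assay reports only a limit, > 1000 nM, and no number. Of the three values shown, a single one sits at that limit (the limit of > 1000 nM in this assay, at which 1 of the 3 values shown sits). Compounds 1 and 2, which carry the shared core at both ends of their linking chain, each give a measured number, and compound 3, which carries it once with a plain saturated chain on the ring amine, does not. Among the measured compounds shown here, no step between measured compounds that differ in one place exists in this set, so there is no measured step to lean on.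

Compound 4 `O=C(O)CCCCCCCCCN1CCC(c2c[nH]c3ccc(NC(=O)c4ccc(F)cc4)cc23)CC1` differs from compound 3 by carboxymethyl in place of hydrogen on a saturated chain carbon, eight bonds along the chain from an amine nitrogen in a ring. With the terminal acid as the sole alteration, the change is expected to shift this assay by no more than the scatter, in either direction, and the step that the limit leaves unreadable from compound 3 to compound 4 is an estimate rather than a measured result. Compound 4 is therefore expected to come out near 2000 nM, within 500 nM to 10000 nM, with a fair chance that this assay again gives only a limit.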

Compound 4, inhibition constant: > 1000 nM
Compound 4: no number, only a limit; the forecaster's own chance of this, stated with the estimate: 60%; the middle value is on the limit's open side.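

No step can be read from compound 3 to compound 4, since in this assay each gives only a limit and no number: the limit of > 1000 nM in this assay, at which 2 of the 4 values shown sit.

Going by these compounds, whether carboxymethyl in place of hydrogen on the saturated chain carbon changes binding at all stays open.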